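A few compounds are considered here, and "the series" means these few. Any claim that something is new, unique, unknown or untested is made for them only; others in the source may bear on it.

The measured compounds in an assay on membranes from HEK293 cells for displacement of a labelled ligand from adenosine receptor A2b (Homo sapiens), read by scintillation counting, with a stated time of 30 min, tested at 1 uM; a higher number here means more inhibition at the concentration tested (going by the name of the read-out), a lower number less inhibition:
compound 1 `CC1=C(C(=O)NC(C)C)C(c2ccsc2)NC(=O)N1` gives 3%
compound 2 `CCSC(=O)C1=C(C)NC(=O)NC1c1ccsc1` gives 17%
compound 3 `CCC(CC)OC(=O)C1=C(C)NC(=O)NC1c1cccs1` gives 6%

Compound 3 stands second highest of the three numbers in this assay. Its nearest neighbour is compound 1, whose number is lower by an amount within the scatter, so no order between the two can be read. Compound 2 lies furthest from compound 3, with a number higher beyond the scatter. Within the data shown here, the only single-point step among the measured compounds is a number 14 percentage points higher from compound 1 to compound 2 (beyond the scatter), a modest rise that concerns the group on the carbonyl carbon, not the ring on the saturated ring carbon.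

Compound 4 `CCC(CC)OC(=O)C1=C(C)NC(=O)NC1c1ccsc1` differs from compound 3 in one place: thiophen-3-yl in place of thiophen-2-yl on a saturated ring carbon. Among the measured compounds shown here, no measured pair isolates this change; compounds 1 and 2 carry the thiophen-3-yl ring but also differ from compound 3 on the carbonyl carbon, so they do not bear on it directly. For the measured compounds named here, with no step to lean on, a change beyond the scatter is not expected in this assay for compound 4. For compound 4 the expected step is no change at the digits printed from compound 3 to compound 4 (within the scatter). Compound 4 is therefore estimated at 6%, with a range from -4% to 18%.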

Compound 4, a percentage reported as inhibition, at one concentration (the size of the read-out at that concentration, not a potency): 26%
Compound 4: the middle estimate sits 20 percentage points below what was measured; measured number outside the range, above it.
By their numbers in this assay, from the lowest: compounds 1 and 3 (each within the scatter of the next); then compounds 2 and 4 (each within the scatter of the next).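

In this assay, among these compounds, thiophen-3-yl in place of thiophen-2-yl on the saturated ring carbon gives a number 20 percentage points higher from compound 3 to compound 4 (beyond the scatter), so this position responds to how the same ring is attached, which no earlier pair could isolate. With thiophen-3-yl held, the group on the carbonyl carbon separates the compounds only in part: (pentan-3-yl)oxy in place of ethylsulfanyl gives a number 9 percentage points higher from compound 2 to compound 4 (within the scatter), and in place of isopropylamino it gives a number 23 percentage points higher from compound 1 to compound 4 (beyond the scatter), so only the amide stands apart. Nothing at hand bears on the reason for these steps.

The compounds leave open whether the same ring swap gives a like step with ethylsulfanyl or isopropylamino on the carbonyl carbon, as thiophen-2-yl appears here only with (pentan-3-yl)oxy. In this assay they also leave open how a phenyl ring on the saturated ring carbon would fare.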